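Aryl ether variation in a chain-linked series

This account rests on a few compounds, and the source may have more. Where it says the series, first, only, none or still open, it means among the compounds named here.

Three compounds carry results in a functional assay on HepG2 cells (Homo sapiens) for antiproliferative activity, read by MTT assay, with a stated time of 72 h; on this read-out lower numbers stand for stronger inhibition and higher numbers for weaker inhibition. Compound 1 `Cc1nn(C)c(Oc2ccc(Cl)cc2)c1/C=N\CCCCCOc1cc2oc(=O)cc(C)c2cc1Cl` gives 15300 nM. Compound 3 `Cc1nn(C)c(Oc2ccccc2Br)c1/C=N\CCCCCCOc1cc2oc(=O)cc(C)c2cc1Cl` gives 24200 nM. For compound 2 `Cc1nn(C)c(Oc2cccc(F)c2)c1/C=N\CCCCCCOc1cc2oc(=O)cc(C)c2cc1Cl` the assay reports only a limit, > 25000 nM. Of the two numbers, compound 3 stands at the top, though compound 1 sits within the scatter of it. Among the measured compounds shown here, the single one-place step between measured compounds, an at least 1.0-fold lower number from compound 2 to compound 3 (0.01 log units; that floor lies within the scatter), starts from the limit of > 25000 nM in this assay, at which 1 of the 3 values shown sits, and shows nothing beyond the scatter.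

Compound 4 `Cc1nn(C)c(Oc2ccc(OC(F)(F)F)cc2)c1/C=N\CCCCCCOc1cc2oc(=O)cc(C)c2cc1Cl` differs from compound 3 by 4-(trifluoromethoxy)phenyl in place of 2-bromophenyl on an oxygen on an aromatic ring. For the measured compounds named here, the only measured step on this oxygen-borne aryl group, an at least 1.0-fold lower number from compound 2 to compound 3 (0.01 log units; that floor lies within the scatter), bears on it and lay within the scatter; compound 1 and compound 3, which also differ in chain length, sit within the scatter of each other as well. No step beyond the scatter in this assay is therefore expected in either direction. Compound 4 is estimated at 22000 nM, within 9000 nM to 50000 nM, meaning an expected step of a 1.1-fold lower number from compound 3 to compound 4 (0.04 log units; within the scatter).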

Compound 4, half-maximal inhibitory concentration: 8160 nM
Beside the measured number, compound 4's estimate is 2.7-fold (0.43 log units) above it; measured number outside the range, below it.
By their numbers in this assay, from the lowest: compounds 4, 1 and 3 (each within the scatter of the next, the first and the last beyond it). At a limit, above all of these: compound 2.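

In this assay, the aryl group on the oxygen now yields a step beyond the scatter, which the earlier step on this group did not: a 3.0-fold lower number from compound 3 to compound 4 (0.47 log units; beyond the scatter). Replacing 3-fluorophenyl with 4-(trifluoromethoxy)phenyl also gives a step beyond the scatter, an at least 3.0-fold lower number from compound 2 to compound 4 (0.48 log units; beyond the scatter), so this aryl position can shift the read-out by more than the scatter on this chain. That step has only a floor, and compound 2 carries no number, only a limit: the limit of > 25000 nM in this assay, at which 1 of the 4 values shown sits.

The compared groups differ in both substituent and ring position, so these results cannot separate the two contributions; a 4-bromophenyl or 2-(trifluoromethoxy)phenyl group would do so. On these data alone, whether the trend extends to a carboxylic acid or an amine on this aryl ring remains open.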